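This account rests on a few compounds, and the source may have more. Where it says the series, first, only, none or still open, it means among the compounds named here.

Measured compounds:
- compound 1 `C1=C(c2cncc(OCc3ccccc3)c2)CC2CNCC1C2`: 44 nM
- compound 2 `Clc1ccc(C2=CC3CNCC(C2)C3)nn1`: 73 nM
- compound 3 `FC(F)(F)c1cncc(C2=CC3CNCC(C2)C3)c1`: 79 nM

All three share the same bicyclic amine core and were tested in an in vitro assay on SH-SY5Y cells for displacement of a labelled ligand from Neuronal acetylcholine receptor; alpha3/beta4 (Homo sapiens); on this read-out higher numbers stand for weaker inhibition and lower numbers for stronger inhibition. Compound 1 gives the lowest of the three numbers, at 44 nM. Compound 2, at 73 nM, and compound 3, at 79 nM, both stand close to it, and the gaps from compound 1 to each of them lie within the usual scatter, so none of the three can be set apart from the others.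

Compound 4 `COc1cccc(Oc2cncc(C3=CC4CNCC(C3)C4)c2)c1` has not yet been measured. It differs from compound 1 in one place: 3-methoxyphenyl in place of benzyl on an oxygen on an aromatic ring. Among the compounds with values here, no pair among the measured compounds shows what such an exchange does on this read-out, so the size of the step from compound 1 to compound 4 cannot be read from a measured precedent. Given the closeness of all three measured values, compound 4 is expected to land near compound 1, with a step of a 1.4-fold higher number from compound 1 to compound 4 (0.13 log units; within the scatter) that may not exceed the scatter. Compound 4 is therefore estimated at 60 nM, between 20 nM and 180 nM.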

Compound 4, inhibition constant: 15 nM
Compound 4: middle estimate off by 4.0-fold (0.60 log units), on the high side; measured number outside the range, below it.
By their numbers in this assay, from the lowest: compound 4; then compounds 1, 2 and 3 (each within the scatter of the next).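

In this assay, putting 3-methoxyphenyl in place of benzyl on an oxygen on an aromatic ring gives a 2.9-fold lower number from compound 1 to compound 4 (0.47 log units; beyond the scatter), the only step shown here that lies beyond the scatter. Within the data shown here, this shows that the number responds to the group carried on that oxygen, which the earlier compounds could not show, as they stood within the scatter of one another and no pair among them differed in one place. Nothing measured here accounts for this step.

Among these compounds, the single exchange replaces benzyl as a whole, so it remains open whether the lower number belongs to the methoxy group or to the change from benzyl to a substituted phenyl ring. Also open, as far as these compounds go, is how plain phenyl, or 3-methoxyphenyl with a hydroxyl or an amine in place of its methoxy group, would stand on this read-out.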